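Cyano in Place of Benzoyl on the Sulfonyl-Bearing Alkene

The source may hold more compounds than are shown below. What is called first, only, known or untested is meant among the compounds shown, and "the series" means these compounds.

Measured compounds:
- compound 1 `COc1ccc2[nH]c(-c3ccccc3)c(C=C(C#N)C#N)c2c1`: 2400 nM
- compound 2 `CC(=O)/C(=C\c1c(-c2ccccc2)[nH]c2ccccc12)S(=O)(=O)c1ccccc1`: 5000 nM
- compound 3 `O=C(/C(=C\c1c(-c2ccccc2)[nH]c2ccccc12)S(=O)(=O)c1ccccc1)c1ccccc1`: 39500 nM

In a functional assay on Hs-578T cells (Homo sapiens) for inhibition, read by sulforhodamine B assay, with a stated time of 48 h (on this read-out lower numbers stand for stronger inhibition of growth and higher numbers for weaker inhibition of growth), compound 3 gives the highest of the three numbers; compound 2 lies nearest, and compound 1 sits furthest away with the lowest number. Among the measured compounds shown here, the only step that touches this part of the molecule is a 7.9-fold higher number from compound 2 to compound 3 (0.90 log units; beyond the scatter), where the carbonyl substituent grew from methyl to phenyl. Compound 4 `N#C/C(=C\c1c(-c2ccccc2)[nH]c2ccccc12)S(=O)(=O)c1ccccc1` reverses that direction more sharply: cyano in place of benzoyl on a double-bonded chain carbon bound to a double-bonded chain carbon and a sulfonyl sulfur. The resulting group matches the cyano already seen in compound 1, whose value in this assay is far below that of compound 3. A drop beyond the scatter is therefore expected, landing compound 4 near compound 2 and compound 1, with an estimated step of a 9.9-fold lower number from compound 3 to compound 4 (0.99 log units; beyond the scatter). Compound 4 is estimated at 4000 nM, within 1500 nM to 12000 nM.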

Compound 4, concentration for 50% growth inhibition: 23600 nM
Compound 4: middle estimate off by 5.9-fold (0.77 log units), on the low side; measured number above the stated range.
By their numbers in this assay, from the lowest: compound 1; then compound 2; then compounds 4 and 3 (each within the scatter of the next).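

In this assay, cyano in place of benzoyl gives a 1.7-fold lower number from compound 3 to compound 4 (0.22 log units; within the scatter) and so leaves these two groups indistinguishable at this position. Cyano in place of acetyl gives a 4.7-fold higher number from compound 2 to compound 4 (0.67 log units; beyond the scatter) at the same place, which makes acetyl the one group of the three that stands apart from both others on this read-out. No supporting measurement is available to explain this result. The compounds shown leave open how an amide, a carboxylic acid or a methyl ester would behave on this double-bonded chain carbon.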